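Hydroxy ester in place of acetoxy ether on the core

The source may report more compounds than this note shows. Statements on the series, on what has been measured and on what is new or still open speak of the compounds shown alone.

Compound 3 `CCC(CO[C@H](CC=C(C)C)C1=CC(=O)c2c(O)ccc(O)c2C1=O)OC(C)=O` gives 25400 nM in a functional assay on DU-145 cells (Homo sapiens) for cytotoxicity, read by MTT assay; a lower number here means a stronger inhibitor, a higher number a weaker inhibitor. Among the three numbers so far it stands second highest: compound 2 `CC(C)=CC[C@@H](OC[C@@H](C)O)C1=CC(=O)c2c(O)ccc(O)c2C1=O` gives 14300 nM and compound 1 `CCCCC(O)CC(=O)O[C@H](CC=C(C)C)C1=CC(=O)c2c(O)ccc(O)c2C1=O` gives 45300 nM. Within the data shown here, the step of a 1.8-fold higher number from compound 2 to compound 3 (0.25 log units; within the scatter) and the step of a 1.8-fold lower number from compound 1 to compound 3 (0.25 log units; within the scatter) both lie within the scatter, so compound 3 is not separated from either neighbour; the only step beyond the scatter is a 3.2-fold lower number from compound 1 to compound 2 (0.50 log units; beyond the scatter), a modest one.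

Compound 4 `CC(C)=CC[C@@H](OC(=O)CCO)C1=CC(=O)c2c(O)ccc(O)c2C1=O` differs from compound 3 by (2-hydroxyethyl)carbonyl in place of 2-acetoxybutyl on an oxygen on a saturated carbon. The change brings back an ester bearing a hydroxyl, as in compound 1, but with a shorter chain. Among the measured compounds shown here, the step of a 1.8-fold lower number from compound 1 to compound 3 (0.25 log units; within the scatter) is the closest precedent and runs within the scatter; the step of a 3.2-fold lower number from compound 1 to compound 2 (0.50 log units; beyond the scatter), read in reverse, points to a somewhat higher number when a hydroxy ester replaces an ether. A small rise, at or just beyond the scatter, is therefore expected in this assay. Compound 4 is estimated to give 35000 nM, in the range 15000 nM to 80000 nM. That estimate corresponds to the expected step of a 1.4-fold higher number from compound 3 to compound 4 (0.14 log units; within the scatter).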

Compound 4, half-maximal inhibitory concentration: 55300 nM
The estimate for compound 4 lay 1.6-fold (0.20 log units) below the measured number; the range from low to high includes it.
By their numbers in this assay, from the lowest: compounds 2, 3, 1 and 4 (each within the scatter of the next, the first and the last beyond it).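

The hydroxy ester on the oxygen on a saturated carbon now separates from both ethers in this assay (a 2.2-fold higher number from compound 3 to compound 4 (0.34 log units; beyond the scatter); a 3.9-fold higher number from compound 2 to compound 4 (0.59 log units; beyond the scatter)), though both steps are modest. Removing the butyl from the ester chain does not separate the two hydroxy esters (a 1.2-fold higher number from compound 1 to compound 4 (0.09 log units; within the scatter)), so chain length on the ester side has no readable effect across this pair. Ester over ether therefore gives the higher number in three of the four comparisons, with compound 1 against compound 3 the exception, and no measurement on hand explains the difference.

As far as these compounds go, it remains open whether the hydroxyl itself matters, since an unsubstituted acetyl ester would test the ester alone. An amine or a carboxylic acid in place of that hydroxyl on the (2-hydroxyethyl)carbonyl would also show whether the end of the chain can shift the number at all.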